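Anilinopyrimidine series: swapping the pyridine for thiophene

The source may hold more compounds than are shown below. What is called first, only, known or untested is meant among the compounds shown, and "the series" means these compounds.

Working notes on two measured compounds and one still open. Going by the values given here, compound 1 `CC1CCN(c2cccc(Nc3nccc(-c4cccs4)n3)c2)CC1` and compound 2 `c1ccc(Nc2nccc(-c3ccncc3)n2)cc1` share the anilinopyrimidine core but differ in two places, so no single step can be drawn between them; only their two values can be set side by side. In a functional assay for inhibition, with Homo sapiens as the target (on this read-out lower numbers stand for stronger inhibition and higher numbers for weaker inhibition), compound 1 gives 3500 nM, while compound 2 gives 900 nM. Compound 2 thus holds the lowest number of the two, and the gap to compound 1 lies beyond the usual scatter.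

Compound 3 `c1ccc(Nc2nccc(-c3cccs3)n2)cc1` is the next point. Relative to compound 2 the change is thiophen-2-yl in place of pyridin-4-yl on an aromatic carbon next to the ring nitrogen. Among the compounds with values here, the only thiophen-2-yl compound measured so far is compound 1, whose weaker value 3500 nM is confounded by its second difference, so no clean precedent exists.

For compound 3 a modest step toward weaker inhibition is expected, a 1.7-fold higher number from compound 2 to compound 3 (0.22 log units; within the scatter), with wide uncertainty. The estimate for compound 3 is 1500 nM, within a range from 500 nM to 5000 nM.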

Compound 3, half-maximal inhibitory concentration: 31700 nM
Compound 3: the middle estimate sits 21-fold (1.32 log units) below what was measured, and the stated range ends below it.
By their numbers in this assay, from the lowest: compound 2; then compound 1; then compound 3.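

On the aromatic carbon next to the ring nitrogen, the identity of the aromatic ring matters strongly in this assay: thiophen-2-yl in place of pyridin-4-yl gives a 35-fold higher number from compound 2 to compound 3 (1.55 log units; beyond the scatter), although the two groups match in hydrogen-bond donors and acceptors. Compound 1 could not show this, as its thiophen-2-yl value came with a second difference from compound 2. Compound 3 also gives a one-place reading of that second site, where hydrogen in place of 4-methylpiperidin-1-yl gives a 9.1-fold higher number from compound 1 to compound 3 (0.96 log units; beyond the scatter), so with thiophen-2-yl held constant, the compound carrying 4-methylpiperidin-1-yl has the lower number.

No measurement at hand accounts for either step. As far as these compounds go, it remains open whether 4-methylpiperidin-1-yl would lower the number to a similar extent alongside pyridin-4-yl, and where a phenyl ring or a pyridin-3-yl group would fall at the position next to the ring nitrogen.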